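Lengthening the acyl chain on the shared core

This account rests on a few compounds, and the source may have more. Where it says the series, first, only, none or still open, it means among the compounds named here.

Compound 1 `COc1ccc(N)c(C2=NN(C(C)=O)C(C)(C)S2)c1`: 77.1%
Compound 2 `CC1(C)SC(c2ccccc2N)=NN1C(=O)c1ccccc1`: 39.8%
Compound 3 `CCC(=O)N1N=C(c2cc(OC)ccc2N)SC1(C)C`: 73%

In an assay on isolated protein for inhibition of Nitric oxide synthase, inducible (Homo sapiens), read by scintillation counting, with a stated time of 30 min, tested at 50 uM (a lower number here means less inhibition, a higher number more inhibition at the concentration tested (going by the name of the read-out)), compound 3 gives 73%, the second highest of the three numbers. Compound 1 gives 77.1%, and the step of a number 4.1 percentage points lower from compound 1 to compound 3 (within the scatter) lies within the scatter. Compound 2 gives 39.8%, well beyond the scatter below compound 3. The unmeasured compound 4 `CCCC(=O)N1N=C(c2cc(OC)ccc2N)SC1(C)C` differs from compound 3 by methyl in place of hydrogen on a saturated chain carbon, two bonds along the chain from a carbonyl carbon. Within the data shown here, the only measured step that bears on this kind of change is a number 4.1 percentage points lower from compound 1 to compound 3 (within the scatter), which did not move the read-out beyond the scatter, so compound 4 is expected to show a number 3 percentage points lower from compound 3 to compound 4 (within the scatter), no step beyond the scatter. Compound 4 is therefore estimated at 70%, with a range from 55% to 82%.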

Compound 4, a percentage reported as inhibition, at one concentration (the size of the read-out at that concentration, not a potency): 91.1%
Estimate against measurement, compound 4: 21.1 percentage points below; measured number outside the range, above it.
By their numbers in this assay, from the lowest: compound 2; then compounds 3 and 1 (each within the scatter of the next); then compound 4.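

In this assay the methyl two bonds along the chain from a carbonyl carbon moves the read-out in a step that is a number 18.1 percentage points higher from compound 3 to compound 4 (beyond the scatter) and so differs from the earlier methyl on the chain carbon bound to a carbonyl carbon, which gave a number 4.1 percentage points lower from compound 1 to compound 3 (within the scatter) without leaving the scatter. Read as ethyl in place of hydrogen, the change gives a number 14 percentage points higher from compound 1 to compound 4 (beyond the scatter) and shows that on this acyl chain the outcome depends on where the carbon is added. Nothing measured here explains this rise.

From the compounds shown here alone, whether a longer chain than propylcarbonyl continues the rise remains open. So does whether an amine or a carboxylic acid at the end of the chain would keep it.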